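A Fluorine Added to the Phenyl Ring of Compound 2

This account rests on a few compounds, and the source may have more. Where it says the series, first, only, none or still open, it means among the compounds named here.

Two compounds were characterized in an in vivo ADME assay on the whole organism for pharmacokinetics, with Canis familiaris (Canis lupus familiaris) as the target, at a dose of 0.5 mg/kg by the intravenous route; on this read-out lower numbers stand for narrower distribution and higher numbers for wider distribution into tissues. Compound 1, `COc1cc2c(cc1OC)CN(c1nc(N3CCCN(C(=O)N4CC(O)C(O)C4)CC3)nc3cc(OC)c(OC)cc13)CC2`, gives 10 L/kg in this assay. Compound 2, `COc1cc2nc(N3CCCN(C(=O)N4CCOCC4)CC3)cc(N)c2c(-c2ccccc2)c1OC`, gives 2.8 L/kg in this assay. Among these two numbers compound 2 stands lowest; its nearest neighbour is compound 1, whose number is higher by a margin that lies beyond the usual scatter of repeated measurements. The two compounds share no single point of difference, so their gap says nothing about any one structural change.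

Compound 3, `COc1cc2nc(N3CCCN(C(=O)N4CCOCC4)CC3)cc(N)c2c(-c2ccc(F)cc2)c1OC`, has not yet been measured. It differs from compound 2 in one place: fluoro in place of hydrogen on an aromatic carbon. Among the compounds with values here, no pair of measured compounds shows this change, so its effect in this assay is not known from the present data. A single fluorine on the phenyl ring is a small alteration, and the step is expected to stay within the scatter. On that basis compound 3 is estimated at 3 L/kg in this assay, with a range from 1.5 L/kg to 6 L/kg. The expected step of a 1.1-fold higher number from compound 2 to compound 3 (0.03 log units; within the scatter) is therefore essentially none.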

Compound 3, volume of distribution in the Canis familiaris assay: 4.8 L/kg
Estimate against measurement, compound 3: 1.6-fold (0.20 log units) below; measured number inside the range.
By their numbers in the Canis familiaris assay, from the lowest: compounds 2 and 3 (each within the scatter of the next); then compound 1.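

Within the data shown here, in the Canis familiaris assay, compounds 2 and 3 form the first measured pair that differs in only one place, and the change from phenyl to 4-fluorophenyl gives a 1.7-fold higher number from compound 2 to compound 3 (0.23 log units; within the scatter). At this position, para to a large group, fluoro in place of hydrogen therefore leaves the volume of distribution within what repeated measurements would show, a reading that neither compound 1 nor compound 2 could give alone. In a physicochemical assay for acid dissociation, compound 2 gives 8.5 and compound 3 gives 8.5, with no change at the digits printed from compound 2 to compound 3 (within the scatter), and nothing measured for these compounds offers an explanation for either result.

The compounds shown leave open whether this position would read the same with a group larger than fluoro, such as trifluoromethyl, methoxy or an amine, or with a carboxylic acid on the phenyl ring. They also leave open whether fluoro at another carbon of that ring, or a second fluoro, would stay within the scatter in the Canis familiaris assay, and the gap between compound 1 and the other two compounds remains tied to no single structural change.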